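The source may report more compounds than this note shows. Statements on the series, on what has been measured and on what is new or still open speak of the compounds shown alone.

Values in an ADME assay on Karpas-1106P cells (Homo sapiens) for cytotoxicity; on this read-out higher numbers stand for an effect only at larger amounts of compound and lower numbers for an effect already at smaller amounts:
- Compound 1 `Cc1ccc(S(=O)(=O)N[C@@H](CC(=O)NC(C)(C)C)C(=O)NCCNC(=O)c2cccc(C(C)C)c2)cc1`: > 11100 nM
- Compound 2 `Cc1ccc(S(=O)(=O)N[C@@H](CC(=O)NC(C)(C)C)C(=O)NCCNC(=O)c2ccccc2F)cc1`: > 11100 nM
- Compound 3 `Cc1ccc(S(=O)(=O)N[C@@H](CC(=O)NC(C)(C)C)C(=O)NCCNC(=O)c2ccccc2Cl)cc1`: > 11100 nM

Compound 3 stands at > 11100 nM, which is a limit of the assay and not a number. It shares this position with the other two compounds, and the common mark is the limit of > 11100 nM in this assay, at which 3 of the 3 values shown sit.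

Compound 4 `COc1cc(OC)cc(C(=O)NCCNC(=O)[C@H](CC(=O)NC(C)(C)C)NS(=O)(=O)c2ccc(C)cc2)c1` carries 3,5-dimethoxyphenyl in place of 2-chlorophenyl on a carbonyl carbon.

The nearest measured changes are swaps of the group on that same carbonyl carbon. They are a step that the two limits leave unreadable from compound 1 to compound 3 and a step that the two limits leave unreadable from compound 1 to compound 2, joined by a step that the two limits leave unreadable from compound 2 to compound 3. None of these has a size that can be read, so they offer no measured size to carry over. Given a step that the two limits leave unreadable from compound 1 to compound 3, no step beyond the scatter is expected in this assay, and the assay will most likely report only a limit again. The step expected is a step that the limit leaves unreadable from compound 3 to compound 4. For compound 4 the estimate is 14000 nM, with an expected range from 6000 nM to 30000 nM.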

Compound 4, half-maximal effective concentration: > 11100 nM
Compound 4: no number, only a limit (the forecaster's own chance of this, stated with the estimate: 85%); the middle value does not contradict the limit.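

Compound 4 returns only a limit of the assay, as do compound 1, compound 2 and compound 3, so no step among these compounds can be read: the limit of > 11100 nM in this assay, at which 4 of the 4 values shown sit. The compounds shown leave open how the four groups on that carbonyl carbon rank, and at what concentration any of these compounds has an effect.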